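The source may hold more compounds than are shown below. What is called first, only, known or untested is meant among the compounds shown, and "the series" means these compounds.

The series varies one group on an aromatic nitrogen of the shared core. In a functional assay on HT-29 cells (Homo sapiens) for inhibition, read by luminescence and CellTiter-Glo, with a stated time of 24 h (on this read-out higher numbers stand for an effect only at larger amounts of compound and lower numbers for an effect already at smaller amounts), compound 1 `CN1C(=S)[C@@H](NC(=O)c2nc(Cc3ccccc3)n(CCCF)n2)COc2ccccc21` gives 4760 nM, compound 2 `CN1C(=S)[C@@H](NC(=O)c2nc(Cc3ccccc3)n(C3CCCCCC3)n2)COc2ccccc21` gives 5530 nM, and compound 3 `CN1C(=S)[C@@H](NC(=O)c2nc(Cc3ccccc3)n(Cc3ccccc3)n2)COc2ccccc21` gives 414 nM, the lowest number of the three. The next change leads to compound 4 `CN1C(=S)[C@@H](NC(=O)c2nc(Cc3ccccc3)n(-c3ncccn3)n2)COc2ccccc21`: pyrimidin-2-yl in place of benzyl on an aromatic nitrogen. Here pyrimidin-2-yl stands in place of benzyl on an aromatic nitrogen.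

Within the data shown here, three measured steps bear on this change. a 1.2-fold higher number from compound 1 to compound 2 (0.07 log units; within the scatter) lies within the scatter, and 3-fluoropropyl and cycloheptyl are not separated. an 11-fold lower number from compound 1 to compound 3 (1.06 log units; beyond the scatter) and a 13-fold lower number from compound 2 to compound 3 (1.13 log units; beyond the scatter) are both large, and compound 3 is the only measured compound with benzyl on that nitrogen. Among the measured compounds shown here, no measured compound carries pyrimidin-2-yl, which leaves the estimate wide. With benzyl gone, a clearly higher number is expected in this assay, though probably a smaller step than those two. The expected step is a 4.8-fold higher number from compound 3 to compound 4 (0.68 log units; beyond the scatter). Compound 4 is estimated at 2000 nM, with an expected range from 500 nM to 7000 nM.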

Compound 4, half-maximal effective concentration: 3970 nM
Estimate against measurement, compound 4: 2.0-fold (0.30 log units) below, and the stated range covers the measured number.
By their numbers in this assay, from the lowest: compound 3; then compounds 4, 1 and 2 (each within the scatter of the next).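

In this assay, pyrimidin-2-yl in place of benzyl gives a clear rise (a 9.6-fold higher number from compound 3 to compound 4 (0.98 log units; beyond the scatter)), so a six-membered aromatic ring on this nitrogen does not by itself keep the low number of compound 3. Among these compounds, compound 4 also shows no separation from the non-aromatic groups (a 1.4-fold lower number from compound 2 to compound 4 (0.14 log units; within the scatter); a 1.2-fold lower number from compound 1 to compound 4 (0.08 log units; within the scatter)), which leaves benzyl as the only group here that stands apart from the others. No measurement of any property accompanies these compounds that could account for this step.

The change removes the chain carbon and brings ring nitrogens in together, so the two remain unseparated; phenyl directly on the nitrogen, or pyrimidin-2-ylmethyl, would divide them. From the compounds shown here alone, whether a longer link, as in 2-phenylethyl, or a substituted benzyl such as 4-methoxybenzyl, holds the low number also stays open.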